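Methoxy to methyl in compound 4

A few compounds are considered here, and "the series" means these few. Any claim that something is new, unique, unknown or untested is made for them only; others in the source may bear on it.

In an ADME assay on microsomes from liver (Rattus norvegicus) for metabolic stability, with a stated time of 10 min, tested at 1 uM (a lower number here means that less of the compound is left, a higher number that more of the compound is left), compound 1 (`COc1c(-c2ccc(C(F)(F)F)cc2Cl)ccc2nn([C@@H](CC(C)C)c3ccc(C(=O)NCCC(=O)O)cc3)cc12`) gives 84% and stands within the scatter of compound 3 (`Cc1c(-c2ccc(C(F)(F)F)cc2Cl)ccc2c1cnn2[C@@H](CC(C)C)c1ccc(C(=O)NCCC(=O)O)cc1`), which carries a methyl group on a different core and gives 87% in the same read-out. Compound 2 (`COc1c(-c2ccc(C(F)(F)F)cc2Cl)ccc2nn([C@H](CC(C)C)c3ccc(C(=O)NCCC(=O)O)cc3)cc12`) gives 100% and is the furthest number from compound 1. Compound 4 (`Cc1c(-c2ccc(C(F)(F)F)cc2Cl)ccc2nn([C@@H](CC(C)C)c3ccc(C(=O)NCCC(=O)O)cc3)cc12`) is not yet measured and keeps the core of compound 1, with the change methyl in place of methoxy on an aromatic carbon ortho to a 2-chloro-4-(trifluoromethyl)phenyl group.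

Within the data shown here, the only measured step, a number 16 percentage points higher from compound 1 to compound 2 (beyond the scatter) with a modest size, comes with the fact that compounds 1 and 2 differ only in the configuration as drawn and leaves the methoxy group untouched. Among the measured compounds shown here, it therefore gives no direct guide, and no measured step exchanges methoxy for methyl. Compound 3 at 87% shows a methyl-bearing analogue within the scatter of compound 1. No step beyond the scatter is therefore expected in this assay, and the estimated step of a number 3 percentage points higher from compound 1 to compound 4 (within the scatter) has no firm direction. For compound 4 the estimated value is 87% with an expected range of 74% to 99% in this read-out.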

Compound 4, percent of the compound remaining: 107%
The estimate for compound 4 lay 20 percentage points below the measured number; the whole stated range lies below it.
By their numbers in this assay, from the lowest: compounds 1 and 3 (each within the scatter of the next); then compounds 2 and 4 (each within the scatter of the next).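

In this assay, among these compounds, methyl in place of methoxy on the aromatic carbon ortho to a 2-chloro-4-(trifluoromethyl)phenyl group gives the first direct reading of this position: a number 23 percentage points higher from compound 1 to compound 4 (beyond the scatter). On the core of compound 1, this position therefore moves the read-out beyond the scatter, and the change that does so removes one oxygen and the only hydrogen-bond acceptor of the leaving group. Nothing in hand gives a measured property that accounts for this step.

It remains open whether the same exchange gives a step of this kind in the configuration drawn in compound 2. Also open, from the compounds shown here alone, is how a nitrile or an ethyl group on this aromatic carbon would read in this assay.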